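Pyridin-3-yl in place of hexyl: an expected rise

The source may report more compounds than this note shows. Statements on the series, on what has been measured and on what is new or still open speak of the compounds shown alone.

Compound 1 `COc1ccc2cc(-c3cn(CCCN4C(=O)COc5ccccc54)nn3)ccc2c1` gives > 100000 nM
Compound 2 `COc1ccc(-c2cn(CCCN3C(=O)COc4ccccc43)nn2)cc1` gives 4900 nM
Compound 3 `CCCCCCc1cn(CCCN2C(=O)COc3ccccc32)nn1` gives 100 nM

These values come from a functional assay on HeLa cells (Homo sapiens) for antiproliferative activity, read by sulforhodamine B assay, with a stated time of 48 h; a higher number here means a weaker inhibitor of growth, a lower number a stronger inhibitor of growth. For compound 1 the entry > 100000 nM is a limit of the assay and not a number. Among the two true numbers, compound 3 holds the lower one at 100 nM.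

Compound 4 `O=C1COc2ccccc2N1CCCn1cc(-c2cccnc2)nn1` differs from compound 3 by one change, pyridin-3-yl in place of hexyl on an aromatic carbon. Within the data shown here, one measured step bears directly on this place. It is a 49-fold lower number from compound 2 to compound 3 (1.69 log units; beyond the scatter), a large step in which hexyl replaced 4-methoxyphenyl. Compound 4 gives up hexyl in the same way and again carries an aromatic ring group, as compound 2 does, so the expected movement runs the opposite way, to a higher number in this assay. That expected step, of similar size to the measured one, is estimated as a 50-fold higher number from compound 3 to compound 4 (1.70 log units; beyond the scatter). The estimated value for compound 4 is 5000 nM, with an expected range from 800 nM to 40000 nM.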

Compound 4, concentration for 50% growth inhibition: > 100000 nM
Compound 4 ended at the assay's limit (the forecaster's own chance of this, stated with the estimate: 10%); at least 20-fold (1.30 log units) between middle value and limit.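

In this assay, compound 4 ends at a limit of the assay and not at a number, so the steps from it give only minimum sizes: the limit of > 100000 nM in this assay, at which 2 of the 4 values shown sit.

Even so, they show that this aromatic carbon, two ring bonds from the ring nitrogen, separates more sharply than the earlier compounds revealed, with pyridin-3-yl replacing hexyl giving an at least 1000-fold higher number from compound 3 to compound 4 (3.00 log units; beyond the scatter). Aromatic ring groups are also not interchangeable here, as pyridin-3-yl replacing 4-methoxyphenyl gives an at least 20-fold higher number from compound 2 to compound 4 (1.30 log units; beyond the scatter).

No comparison can be read between compound 1 and compound 4, which rest at the same limit. From the compounds shown here alone, whether a shorter or longer alkyl chain than hexyl, an amine or a carboxylic acid at this place would match compound 3 at 100 nM remains open.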